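The source may hold more compounds than are shown below. What is called first, only, known or untested is meant among the compounds shown, and "the series" means these compounds.

Measured compounds in an ADME assay on Caco-2 cells (Homo sapiens) for permeability, in the apical to basolateral direction; on this read-out higher numbers stand for higher permeability and lower numbers for lower permeability:
- Compound 1 `Cn1cncc1CN1CC(N(CC2CCN(C(=O)CNC(=O)OC(C)(C)C)CC2)S(=O)(=O)c2ccccn2)Cc2cc(C#N)ccc21` gives 0.5 10^-6 cm/s.
- Compound 2 `CCOC(=O)N1CCC(CN(C2Cc3cc(C#N)ccc3N(Cc3cncn3C)C2)S(=O)(=O)c2ccccn2)CC1` gives 2.6 10^-6 cm/s.
- Compound 3 `CCS(=O)(=O)N1CCC(CN(C2Cc3cc(C#N)ccc3N(Cc3cncn3C)C2)S(=O)(=O)c2ccccn2)CC1` gives 0.1 10^-6 cm/s.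

Compound 3 stands lowest of the three: compound 1 sits nearer to it, as shown by a 5.0-fold lower number from compound 1 to compound 3 (0.70 log units; beyond the scatter), and compound 2 sits furthest, as shown by a 26-fold lower number from compound 2 to compound 3 (1.41 log units; beyond the scatter). Compound 4 `Cn1cncc1CN1CC(N(CC2CCN(C(=O)C3CCCC3)CC2)S(=O)(=O)c2ccccn2)Cc2cc(C#N)ccc21` is not yet measured. It differs from compound 3 at one place: cyclopentylcarbonyl in place of ethylsulfonyl on an amine nitrogen in a ring.

Within the data shown here, two measured steps bear on this change, since each of them replaced a carbonyl-bearing group on that ring nitrogen with ethylsulfonyl. The step of a 26-fold lower number from compound 2 to compound 3 (1.41 log units; beyond the scatter) was large, and the step of a 5.0-fold lower number from compound 1 to compound 3 (0.70 log units; beyond the scatter) was modest. Going from compound 3 to compound 4 runs the other way, from ethylsulfonyl back to a carbonyl-bearing group, so a clear rise in this assay is expected, likely of a size between those two steps. The expected step is a 25-fold higher number from compound 3 to compound 4 (1.40 log units; beyond the scatter). Compound 4 is therefore estimated at 2.5 10^-6 cm/s, with a range from 0.7 10^-6 cm/s to 9 10^-6 cm/s.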

Compound 4, apparent permeability: 0.5 10^-6 cm/s
Beside the measured number, compound 4's estimate is 5.0-fold (0.70 log units) above it; measured number below the stated range.
By their numbers in this assay, from the lowest: compound 3; then compounds 1 and 4 (each within the scatter of the next); then compound 2.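

Among these compounds, at this ring nitrogen, the earlier compounds left it unclear how much of the gap to ethylsulfonyl any carbonyl-linked group would recover in this assay; cyclopentylcarbonyl recovers only part of it, giving a 5.0-fold higher number from compound 3 to compound 4 (0.70 log units; beyond the scatter) and leaving compound 3 lowest of the four. What is attached to the carbonyl carbon also counts, as swapping ethoxy for cyclopentyl gives a 5.2-fold lower number from compound 2 to compound 4 (0.72 log units; beyond the scatter) and so places compound 2 highest of the four. Yet two quite different groups on that carbon can give the same reading, since there is no change at the digits printed from compound 1 to compound 4 (within the scatter) for cyclopentyl in place of ((tert-butoxycarbonyl)amino)methyl.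

No measurement here explains why ethoxy stands apart from the other two groups on the carbonyl carbon. Still open, on these data alone, is whether a chain longer than ethoxy, or an amine, on that carbon would keep the higher number.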